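Ester Rearrangement on a Pyrimidinone Series: Microsomal Stability

The source may hold more compounds than are shown below. What is called first, only, known or untested is meant among the compounds shown, and "the series" means these compounds.

Measured so far:
compound 1, `CCCCc1nc(C(C)C)c(CC(=O)OCCC)c(=O)n1Cc1ccc(-c2ccccc2-c2noc(=O)[nH]2)cc1`, 7.2%
compound 2, `CCCCc1nc(C)c(CC(=O)OCC2CCCCC2)c(=O)n1Cc1ccc(-c2ccccc2-c2noc(=O)[nH]2)cc1`, 11.5%
compound 3, `CCCCc1nc(C2CC2)c(CC(=O)OC)c(=O)n1Cc1ccc(-c2ccccc2-c2noc(=O)[nH]2)cc1`, 24.4%

The three compounds share one core and differ in the ester-bearing side chain and in the small group on the core. In an ADME assay on microsomes from liver (Homo sapiens) for metabolic stability, with a stated time of 30 min (a higher number here means that more of the compound is left, a lower number that less of the compound is left), compound 1 gives 7.2%, the lowest of the three numbers. Compound 2 stands within the scatter of compound 1, so no order between these two can be read. Compound 3 stands clearly higher than compound 1, by a difference that lies beyond the scatter, and it is the only one of the three that does so.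

The next compound, compound 4, `CCCCc1nc(C(C)C)c(C(C)C(=O)OCC)c(=O)n1Cc1ccc(-c2ccccc2-c2noc(=O)[nH]2)cc1`, has the same atoms as compound 1 joined differently: 1-(ethoxycarbonyl)ethyl in place of (propoxycarbonyl)methyl on an aromatic carbon. Among the compounds with values here, no pair of measured compounds isolates this change, so the size of the step is not known from the data.

He expects no step beyond the scatter, with, if anything, a slight drift upward. For compound 4 in this assay he estimates 12%, with a range from 4% to 28%, which means an expected step of a number 4.8 percentage points higher from compound 1 to compound 4 (within the scatter).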

Compound 4, percent of the compound remaining: 11%
Estimate against measurement, compound 4: 1 percentage points above; the measured number falls inside the stated range.
By their numbers in this assay, from the lowest: compounds 1, 4 and 2 (each within the scatter of the next); then compound 3.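

In this assay, within the data shown here, placing 1-(ethoxycarbonyl)ethyl in place of (propoxycarbonyl)methyl on the aromatic carbon gives a number 3.8 percentage points higher from compound 1 to compound 4 (within the scatter), and this is the first pair that differs in one place only. With the isopropyl group and the rest of the shared core held fixed, this rearrangement of the same atoms within the side chain does not separate the two compounds, so the pair gives no sign that this particular change matters for the percent of compound remaining. No measurement at hand offers an explanation for this result.

The compounds shown leave open whether this position would respond to a larger change than a rearrangement, such as a carboxylic acid or an amide in place of the ester, or a longer chain on the ester oxygen. Among these compounds, they also leave open whether the same exchange would read alike on a core carrying methyl or cyclopropyl in place of isopropyl, since the only pair that isolates it carries the isopropyl group.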